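The source may hold more compounds than are shown below. What is called first, only, known or untested is meant among the compounds shown, and "the series" means these compounds.

Measured so far in a functional assay on DU-145 cells (Homo sapiens) for inhibition, read by trypan blue exclusion, with a stated time of 96 h; on this read-out higher numbers stand for weaker inhibition of growth and lower numbers for stronger inhibition of growth:
- Compound 1 `CSc1ccc(/C=C(/Sc2ccc(C)cc2)C(=O)c2ccc(Br)cc2)cc1`: 50000 nM
- Compound 2 `O=C(/C(=C\c1c(O)cc(O)cc1O)Sc1ccccc1Br)c1ccc(Br)cc1`: > 100000 nM (a limit, not a number)

Compound 2 stands at the limit of > 100000 nM in this assay, at which 1 of the 2 values shown sits. On these data alone, its true position beyond that limit is unknown.

Compound 3 `Cc1ccc(S/C(=C/c2c(O)cc(O)cc2O)C(=O)c2ccc(Br)cc2)cc1` keeps the rest of compound 2 and changes one group: 4-methylphenyl in place of 2-bromophenyl on a sulfur. In words, 4-methylphenyl sits in place of 2-bromophenyl on a sulfur. Going by the values given here, no measured pair shows this change on its own, so any forecast is tentative.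

Among the compounds with values here, the only guide is compound 1, which also carries 4-methylphenyl on a sulfur but differs elsewhere, and which gives 50000 nM in this assay. A modest move toward stronger inhibition of growth is therefore expected, and the estimated step is an at least 1.6-fold lower number from compound 2 to compound 3 (0.22 log units; that floor lies within the scatter). Another reading at the limit remains quite possible. The estimate for compound 3 is 60000 nM, with an expected range of 20000 nM to 100000 nM.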

Compound 3, concentration for 50% growth inhibition: > 100000 nM
Compound 3: no number, only a limit (the forecaster's own chance of this, stated with the estimate: 45%); middle value at least 1.6-fold (0.22 log units) from the limit.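

In this assay compound 3 gives only a limit, and so does compound 2, so the step between them cannot be read and this swap on the sulfur has no measurable size: the limit of > 100000 nM in this assay, at which 2 of the 3 values shown sit. The new information comes from the other side of the molecule, where 4-methylphenyl stays on the sulfur and 2,4,6-trihydroxyphenyl takes the place of 4-(methylsulfanyl)phenyl, giving an at least 2.0-fold higher number from compound 1 to compound 3 (0.30 log units; that floor lies within the scatter). Going by these compounds alone, this is the only readable comparison so far, and because it is a floor, it shows the least the change could amount to rather than its true size.

On these data alone, it remains open how far beyond the limit either trihydroxyphenyl compound lies. As far as these compounds go, it is also open whether another group on the sulfur, such as a phenyl ring carrying an amine or a carboxylic acid, would give a readable number with 2,4,6-trihydroxyphenyl in place.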